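A few compounds are considered here, and "the series" means these few. Any claim that something is new, unique, unknown or untested is made for them only; others in the source may bear on it.

Values in a physicochemical assay for solubility, in phosphate buffer, at pH 6.5; on this read-out lower numbers stand for lower solubility and higher numbers for higher solubility
- compound 1 `CCOc1cc(CN2CCC(NC(=O)c3ccc(NC)nc3)CC2)cc(OCC)c1F` gives 330 ug/mL
- compound 2 `CCOc1cc(CN2CCC(NC(=O)c3cncc(C)c3)CC2)cc(OCC)c1-c1ccc(F)cc1` gives 94 ug/mL
- compound 3 `CCOc1cc(CN2CCC(NC(=O)c3ccc(NC)nc3)CC2)cc(OCC)c1-c1ccc(F)cc1` gives 153 ug/mL

Compound 1 stands highest of the three. Compound 4 `CCOc1cc(CN2CCC(NC(=O)c3ccc(NC(C)C)nc3)CC2)cc(OCC)c1F` carries isopropyl in place of methyl on a nitrogen on an aromatic ring. For the measured compounds named here, no measured step changes this group. The step that brings in 6-(methylamino)pyridin-3-yl gave a 1.6-fold higher number from compound 2 to compound 3 (0.21 log units; within the scatter) and stayed within the scatter. The step that puts 4-fluorophenyl in place of fluoro gave a 2.2-fold lower number from compound 1 to compound 3 (0.33 log units; beyond the scatter) and was modest. A step no larger than that one is therefore expected, leaning towards a lower number, though the data do not test this direction. The expected step is a 1.4-fold lower number from compound 1 to compound 4 (0.14 log units; within the scatter). For compound 4 the estimate is 240 ug/mL, with an expected range from 110 ug/mL to 450 ug/mL.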

Compound 4, solubility: > 520 ug/mL
Compound 4: only a limit was reported (the forecaster's own chance of this, stated with the estimate: 3%); middle value at least 2.1-fold (0.33 log units) from the limit.
By their numbers in this assay, from the lowest: compounds 2 and 3 (each within the scatter of the next); then compound 1. At a limit, above all of these: compound 4.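

In this assay compound 4 gives only a limit, > 520 ug/mL. Isopropyl in place of methyl on a nitrogen on an aromatic ring, a place no earlier step had changed, gives an at least 1.5-fold higher number from compound 1 to compound 4 (0.19 log units; that floor lies within the scatter), so this change brought no fall in the number. How far the number lies beyond that floor cannot be read: the limit of > 520 ug/mL in this assay, at which 1 of the 4 values shown sits.

Going by these compounds, what a longer chain, a cyclopropyl group or a carboxylic acid on that nitrogen would give stays open. So does the effect of isopropyl in the core of compound 3.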